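Removing the bromo group from compound 1

The compounds below may be only part of what the source reports. "The series", "measured", "known", "first", "only" and "open" are said of these compounds alone.

Compound 1 (`COC(=O)c1scc(-c2ccc(NC(=O)c3ccc(C(F)(F)F)cc3Br)cc2)c1OC`) – 9250 nM
Compound 2 (`COC(=O)c1scc(-c2ccc(NC(=O)c3cccc(OC(F)(F)F)c3)cc2)c1OC`) – 18300 nM
Compound 3 (`COC(=O)c1scc(-c2ccc(NC(=O)c3cc(I)ccc3F)cc2)c1OC`) – 35600 nM

In a functional assay on K562 cells (Homo sapiens) for antiproliferative activity, read by MTT assay, with a stated time of 24 h (on this read-out lower numbers stand for stronger inhibition and higher numbers for weaker inhibition), compound 1 and compound 2 lie within the scatter of each other, while compound 3 carries a higher number than compound 1, beyond the scatter. Compound 4 (`COC(=O)c1scc(-c2ccc(NC(=O)c3ccc(C(F)(F)F)cc3)cc2)c1OC`) has hydrogen in place of bromo on an aromatic carbon. Within the data shown here, no measured pair isolates this change, so the expectation rests on the span from compound 1 (9250 nM) to compound 3 (35600 nM). In this assay a small rise, with no step beyond the scatter, is expected, and the estimated step runs a 1.5-fold higher number from compound 1 to compound 4 (0.18 log units; within the scatter) as its size. For compound 4 the estimated value is 14000 nM (expected range 6000 nM to 33000 nM).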

Compound 4, half-maximal inhibitory concentration: 9260 nM
Compound 4: middle estimate off by 1.5-fold (0.18 log units), on the high side, and the stated range covers the measured number.
By their numbers in this assay, from the lowest: compounds 1, 4, 2 and 3 (each within the scatter of the next, the first and the last beyond it).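

Hydrogen in place of bromo on this aromatic carbon gives (a 1.0-fold higher number from compound 1 to compound 4 (0.00 log units; within the scatter)) in this assay, so this assay does not separate the two groups here, which no earlier pair could show. By contrast, 4-(trifluoromethyl)phenyl in place of 2-fluoro-5-iodophenyl on the carbonyl carbon gives (a 3.8-fold lower number from compound 3 to compound 4 (0.58 log units; beyond the scatter)), although this exchange alters several places and cannot be assigned to one substituent. Nothing available explains either result. Going by these compounds, whether an amine, a methoxy group or a carboxylic acid on this carbon would match hydrogen and bromo remains open, as does the contribution of the trifluoromethyl group.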